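A few compounds are considered here, and "the series" means these few. Any claim that something is new, unique, unknown or untested is made for them only; others in the source may bear on it.

Compound 1, `CN(C)c1ccc(/C=C(/SCc2ccc(Cl)cc2Cl)C(=O)c2ccc(Cl)cc2)cc1`, gives 50000 nM.
Compound 2, `CN(C)c1ccc(/C=C(/Sc2ccc(Br)cc2)C(=O)c2ccc(Cl)cc2)cc1`, gives > 100000 nM, which is a limit of the assay and not a number.
Compound 3, `Cc1ccc(CS/C(=C/c2ccc(N(C)C)cc2)C(=O)c2ccc(Cl)cc2)cc1`, gives > 100000 nM, which is likewise a limit and not a number.

Within the data shown here, in a functional assay on DU-145 cells (Homo sapiens) for inhibition, read by trypan blue exclusion, with a stated time of 96 h (a higher number here means a weaker inhibitor of growth, a lower number a stronger inhibitor of growth), compound 1 stands as the only compound with a number of its own; the other two rest at the limit of > 100000 nM in this assay, at which 2 of the 3 values shown sit. Both measured steps leave compound 1 and change the group carried on the sulfur: an at least 2.0-fold higher number from compound 1 to compound 2 (0.30 log units; that floor lies within the scatter) and an at least 2.0-fold higher number from compound 1 to compound 3 (0.30 log units; that floor lies within the scatter). Between the two limits, a step that the two limits leave unreadable from compound 2 to compound 3.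

Compound 4, `O=C(/C(=C\c1c[nH]c2ccc(Br)cc12)SCc1ccc(Cl)cc1Cl)c1ccc(Cl)cc1`, keeps the sulfur side of compound 1 untouched and changes the other end of the shared core instead: 5-bromo-1H-indol-3-yl in place of 4-(dimethylamino)phenyl on a double-bonded chain carbon bound to a double-bonded chain carbon. Among the measured compounds shown here, no measured step touches this position, so neither of the two changes at the sulfur can be read across to it, and the direction of the step is open. With compound 1 as the only anchor, the step from compound 1 to compound 4 is expected to be a 1.2-fold higher number from compound 1 to compound 4 (0.08 log units; within the scatter). Compound 4 is therefore estimated at 60000 nM, with a range from 15000 nM to 200000 nM, and with a real chance that the assay again reports only a limit.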

Compound 4, concentration for 50% growth inhibition: 10000 nM
Beside the measured number, compound 4's estimate is 6.0-fold (0.78 log units) above it; the measured number lies below the stated range.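

In this assay, among these compounds, the change at this end of the shared core gives the first step with a readable size, and it points toward a stronger inhibitor of growth: a 5.0-fold lower number from compound 1 to compound 4 (0.70 log units; beyond the scatter). With the 2,4-dichlorobenzyl group on the sulfur held fixed, this shows that 4-(dimethylamino)phenyl is not required for growth inhibition at this position, and that 5-bromo-1H-indol-3-yl, a larger group with a second aromatic ring, a bromine and a hydrogen-bond donor, can replace it with a gain. The earlier changes on the sulfur gave no such size, since compound 2 and compound 3 each rest at a limit of the assay: the limit of > 100000 nM in this assay, at which 2 of the 4 values shown sit.

The swap brings in the second ring, the bromine and the donor together, so this one step cannot say which of them matters, and a plain 1H-indol-3-yl group or one carrying a methoxy group or a carboxylic acid in place of the bromine would be needed to separate them. Also open, on these data alone, is whether the gain would carry over to other groups on the sulfur, such as the 4-bromophenyl of compound 2 or the 4-methylbenzyl of compound 3.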